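Moving the Chlorine Within the Series of Compound 2

The compounds below may be only part of what the source reports. "The series", "measured", "known", "first", "only" and "open" are said of these compounds alone.

The study concerns two measured compounds and one not yet measured, all tested in an assay on isolated protein for inhibition of DNA topoisomerase 1 (Homo sapiens), with a stated time of 30 min, tested at 100 uM; a lower number here means a weaker effect, a higher number a stronger effect of the compound at the concentration tested. Compound 1, `Oc1ccc(-c2cc(-c3ccccc3)nc(-c3ccccc3Cl)c2)cc1`, gives 13.6% in this assay. Among the measured compounds shown here, compound 2, `Oc1ccc(-c2cc(-c3cccs3)nc(-c3ccccc3Cl)c2)cc1`, gives 2.2% in this assay, which places it as the lower of the two numbers; the only measured step is a number 11.4 percentage points lower from compound 1 to compound 2 (beyond the scatter).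

Compound 3, `Oc1ccc(-c2cc(-c3ccc(Cl)cc3)nc(-c3cccs3)c2)cc1`, is the next compound, and it differs from compound 2 in one place: 4-chlorophenyl in place of 2-chlorophenyl on an aromatic carbon. For the measured compounds named here, no measured step involves this change; the single step from compound 1 to compound 2 concerns the thiophen-2-yl in place of phenyl and says nothing about where the chlorine sits on the chlorophenyl group. With no bearing step, the account gives no reason to expect a move beyond the scatter in either direction, and compound 3 is estimated at a number 1.8 percentage points higher from compound 2 to compound 3 (within the scatter). Compound 3 is therefore expected to show about 4% in this assay, with a range from 0% to 14%.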

Compound 3, a percentage reported as inhibition, at one concentration (the size of the read-out at that concentration, not a potency): 38.8%
Beside the measured number, compound 3's estimate is 34.8 percentage points below it; the whole stated range lies below it.
By their numbers in this assay, from the lowest: compound 2; then compound 1; then compound 3.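

Placing the chlorine differently on this one ring changes the read-out in this assay by a large amount (a number 36.6 percentage points higher from compound 2 to compound 3 (beyond the scatter)), although 2-chlorophenyl and 4-chlorophenyl have the same atoms. Among the compounds shown here, the only earlier step (a number 11.4 percentage points lower from compound 1 to compound 2 (beyond the scatter)) was a modest one and concerned the other aromatic group, so it showed nothing about the group on the carbon next to the ring nitrogen. This result shows that this position responds to where the chlorine sits, and that within this pair the 4-chlorophenyl group gives the higher number, read at a single concentration and not as a potency. Nothing given here explains why the two arrangements differ.

The compounds shown leave open where 3-chlorophenyl would fall relative to its two isomers, and whether the higher number depends on chlorine at all or would also appear with a methoxy group, an amine or a carboxylic acid in its place on the ring. They also leave open whether the same move of the chlorine would have a similar effect with phenyl standing in place of thiophen-2-yl.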